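The compounds below may be only part of what the source reports. "The series", "measured", "known", "first", "only" and "open" are said of these compounds alone.

Working notes on the series. In an ADME assay on KB cells (Homo sapiens) for cytotoxicity, read by resazurin assay, with a stated time of 72 h (a lower number here means a stronger inhibitor, a higher number a weaker inhibitor), compound 1 `O=C(/C=C/c1ccccc1)c1cccc(Br)c1` gives 18400 nM and compound 2 `O=C(/C=C/c1cccnc1)c1ccccc1` gives 7700 nM. Compound 3 `O=C(/C=C/c1cccnc1)c1ccccc1Br` gives no number, only a limit: > 300000 nM. That result is the limit of > 300000 nM in this assay, at which 1 of the 3 values shown sits.

The next structure is compound 4 `COc1ccccc1C(=O)/C=C/c1cccnc1`, which carries methoxy in place of bromo on an aromatic carbon, ortho to a large group: methoxy in place of bromo on an aromatic carbon.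

For the measured compounds named here, one measured step bears on this change: an at least 38-fold higher number from compound 2 to compound 3 (1.59 log units; beyond the scatter), with bromo in place of hydrogen on an aromatic carbon. On these data alone, it is large and beyond the scatter, though its full size is unknown since it ends at a limit. Compound 4 no longer has the bromo of that step, so some return towards compound 2 at 7700 nM is expected. Going by the values given here, no methoxy compound has been measured here, so a full return cannot be assumed, and compound 4 could itself still reach the limit.

In this assay, the expected change is a large one towards a lower number, given as an at least 10-fold lower number from compound 3 to compound 4 (1.00 log units; beyond the scatter). Compound 4 is estimated at 30000 nM, with an expected range of 7000 nM to 150000 nM.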

Compound 4, half-maximal inhibitory concentration: 22700 nM
Beside the measured number, compound 4's estimate is 1.3-fold (0.12 log units) above it; the measured number falls inside the stated range.
By their numbers in this assay, from the lowest: compound 2; then compounds 1 and 4 (each within the scatter of the next). At a limit, above all of these: compound 3.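

At this position, ortho to a large group, the outcome in this assay depends on which group is present and not simply on hydrogen being replaced, as methoxy in place of bromo gives an at least 13-fold lower number from compound 3 to compound 4 (1.12 log units; beyond the scatter). Methoxy in place of hydrogen still counts against compound 4, with a 2.9-fold higher number from compound 2 to compound 4 (0.47 log units; beyond the scatter), a modest step that lies beyond the scatter, so the return towards compound 2 is only partial. The full size of the first step stays unknown, as compound 3 has a limit and not a number: the limit of > 300000 nM in this assay, at which 1 of the 4 values shown sits.

Only hydrogen, bromo and methoxy are shown at this position, so it remains open how a fluoro, a hydroxy, an amine or a carboxylic acid there would read in this assay. On these data alone, it also remains open whether bromo and methoxy at this position would give steps of the same direction and size on the core of compound 1.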